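The source may report more compounds than this note shows. Statements on the series, on what has been measured and on what is new or still open speak of the compounds shown alone.

Working notes on the series. Three compounds have been run in an ADME assay on microsomes from liver (Homo sapiens) for metabolic stability, read by LC-MS, using NADPH, with a stated time of 1 h, tested at 10 uM; a lower number here means that the compound disappears faster, a higher number that the compound lasts longer. Compound 1, `Cc1cc(-c2nc(CN3CCCC3)nn2C)ccc1C(F)(F)F`, gives 1.25 h in this assay. Compound 2, `Cn1nc(CN2CCN(c3ccccc3)CC2)nc1-c1ccc(C(C)(C)C)cc1`, gives 0.622 h. Compound 3, `Cn1nc(CN2CCCC2)nc1-c1ccc(C2(C(F)(F)F)CC2)cc1`, gives 2.87 h, the highest of the three numbers; its gaps to compound 1 and to compound 2 both lie beyond the usual scatter, so compound 3 lasts longest of the measured set. Within the data shown here, no pair of measured compounds differs in a single place, so no single step can be read directly.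

The next compound to be measured is compound 4, `Cn1nc(CN2CCCC2)nc1-c1ccc(C(C)(C)C)cc1`. It differs from compound 3 in one place: tert-butyl in place of 1-(trifluoromethyl)cyclopropyl on an aromatic carbon. Compound 2 also carries a tert-butyl on its aromatic ring and gives the lowest number, but it differs from compound 4 elsewhere as well, so it is only a loose pointer. The step from compound 3 to compound 4 in this assay is expected to be downward and beyond the scatter, a 2.6-fold lower number from compound 3 to compound 4 (0.42 log units; beyond the scatter). For compound 4 the half-life is estimated at 1.1 h, within a range of 0.5 h to 2.4 h.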

Compound 4, half-life: 1.99 h
For compound 4 the middle estimate is 1.8-fold (0.26 log units) below the measured one; measured number inside the range.
By their numbers in this assay, from the lowest: compounds 2, 1, 4 and 3 (each within the scatter of the next, the first and the last beyond it).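

In this assay, among these compounds, tert-butyl in place of 1-(trifluoromethyl)cyclopropyl on an aromatic carbon, para to a large group, gives a 1.4-fold lower number from compound 3 to compound 4 (0.16 log units; within the scatter), and this is the first single change that can be read directly. At this position, then, the half-life does not separate the two groups, even though the change removes both the three-membered ring and the fluorine atoms. Nothing available bears on the reason for this result.

On these data alone, it remains open whether a different group at this position, such as a nitrile or a chlorine, would move the half-life beyond the scatter. As far as these compounds go, it is also open whether tert-butyl and 1-(trifluoromethyl)cyclopropyl would likewise stay within the scatter of each other on the core of compound 2.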